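The compounds below may be only part of what the source reports. "The series", "measured", "known", "first", "only" and "open" are said of these compounds alone.

Measured compounds:
compound 1, `COc1ccc(-c2cn3ccnc(N)c3n2)cc1`, 1%
compound 2, `O=C(Nc1nccn2cc(-c3ccccc3)nc12)c1ccccc1`, 18%
compound 3, `O=C(Nc1nccn2cc(-c3ccccc3)nc12)c1cccnc1`, 24%

These three compounds were tested in an assay on cells for displacement of a labelled ligand from adenosine receptor A1 (Homo sapiens), read by scintillation counting, with a stated time of 120 min, tested at 1 uM; a higher number here means more inhibition at the concentration tested (going by the name of the read-out), a lower number less inhibition. Compound 2 stands second of the three numbers; its nearest neighbour is compound 3, and the step of a number 6 percentage points higher from compound 2 to compound 3 (within the scatter) lies within the scatter. Compound 1, which differs from compound 2 in two places, lies furthest away, and the gap between compound 1 and compound 2 lies beyond the scatter.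

The unmeasured compound 4, `COc1ccc(-c2cn3ccnc(NC(=O)c4ccccc4)c3n2)cc1`, differs from compound 2 in one place: methoxy in place of hydrogen on an aromatic carbon. Cut one bond further out, the same change reads phenyl to 4-methoxyphenyl.

Among the compounds with values here, only one measured step exists, and it concerns a different part of the molecule: the exchange of the group on the carbonyl carbon, which moved the number within the scatter. Within the data shown here, no measured step shows what adding methoxy on this aromatic ring does while the benzoyl amide is kept. Nothing in the data therefore points in either direction, and a step of no size beyond the scatter is expected for a number 2 percentage points higher from compound 2 to compound 4 (within the scatter). Compound 4 is estimated at 20% in this assay, within a range from 4% to 40%.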

Compound 4, a percentage reported as inhibition, at one concentration (the size of the read-out at that concentration, not a potency): 1%
Compound 4: middle estimate off by 19 percentage points, on the high side, and the stated range ends above it.
By their numbers in this assay, from the lowest: compounds 1 and 4 (each within the scatter of the next); then compounds 2 and 3 (each within the scatter of the next).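

In this assay, methoxy on the aromatic carbon para to a large group is a change that moves the number beyond the scatter (a number 17 percentage points lower from compound 2 to compound 4 (beyond the scatter)), so this position on the ring is not indifferent while the benzoyl amide is kept. The earlier step, on the other side of the molecule, had stayed within the scatter (a number 6 percentage points higher from compound 2 to compound 3 (within the scatter)), so the ring carrying the methoxy now stands out as the place where a single change made a visible difference. With the methoxy in place, benzoyl on the nitrogen brings no gain over hydrogen (no change at the digits printed from compound 1 to compound 4 (within the scatter)), and nothing available here explains why the methoxy lowers the number or why benzoyl then adds nothing.

The compounds shown leave open whether the drop belongs to methoxy itself or would also follow from another group at this place, such as a fluorine, a hydroxyl or an amine. Also open, on these data alone, is what the pyridin-3-yl amide of compound 3 would do with a 4-methoxyphenyl group in place of its phenyl.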